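Cinnamanilide series: amino in place of methoxy on compound 1

The compounds below may be only part of what the source reports. "The series", "measured", "known", "first", "only" and "open" are said of these compounds alone.

Compound 1 `COc1cccc(/C=C/C(=O)Nc2cc(OC)c(OC)c(OC)c2)c1`: 12500 nM
Compound 2 `C=C(Br)C(=O)Nc1cccc(/C=C/C(=O)NCc2ccc(C)cc2)c1`: 740 nM

Going by the values given here, in a functional assay on Jurkat cells (Homo sapiens) for inhibition, read by MTT assay, with a stated time of 72 h (a higher number here means a weaker inhibitor, a lower number a stronger inhibitor), compound 1 gives 12500 nM, the highest of the two numbers; compound 2 gives 740 nM, a gap beyond the scatter with no single-point step connecting the pair. Compound 3 `COc1cc(NC(=O)/C=C/c2cccc(N)c2)cc(OC)c1OC` differs from compound 1 in one place: amino in place of methoxy on an aromatic carbon. Among the compounds with values here, no measured pair shows this exchange, so the effect is untested. A step from compound 1 to compound 3 of a 1.4-fold lower number from compound 1 to compound 3 (0.14 log units; within the scatter) is expected, hardly beyond the scatter. Compound 3 is estimated at 9000 nM, with a range from 3000 nM to 30000 nM.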

Compound 3, half-maximal inhibitory concentration: 43300 nM
Compound 3: middle estimate off by 4.8-fold (0.68 log units), on the low side; the whole stated range lies below it.
By their numbers in this assay, from the lowest: compound 2; then compound 1; then compound 3.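

In this assay, going by these compounds alone, the exchange of 3-methoxyphenyl for 3-aminophenyl gives a 3.5-fold higher number from compound 1 to compound 3 (0.54 log units; beyond the scatter), the first single-place step, so this position is not indifferent to the group it carries. Of the two groups, methoxy goes with the lower number, and amino adds a hydrogen-bond donor where methoxy has none. No measurement at hand gives a cause for this step.

On these data alone, whether a hydroxyl, a dimethylamino or an acetamide group at this place would keep the number of compound 1 stays open. Compound 2 differs from compound 1 in more than one place, so its lower number says nothing about this position.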